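Thiophen-3-yl for ethynyl on the shared core

The source may report more compounds than this note shows. Statements on the series, on what has been measured and on what is new or still open speak of the compounds shown alone.

Compound 2 `C#Cc1cn([C@@H]2O[C@H](CO)[C@@H](O)[C@H]2O)c2ncnc(N(C)C)c12` carries a dimethylamino group on the shared core and an ethynyl group on the five-membered ring. In a functional assay on HL-60 cells (Homo sapiens) for antiproliferative activity, read by XTT assay, with a stated time of 72 h (on this read-out lower numbers stand for stronger inhibition and higher numbers for weaker inhibition), compound 2 gives 290 nM, the highest of the two numbers shown; its nearest neighbour is compound 1 `C#Cc1cn([C@@H]2O[C@H](CO)[C@@H](O)[C@H]2O)c2ncnc(OC)c12`, which gives 190 nM in this assay, and the only measured step, a 1.5-fold higher number from compound 1 to compound 2 (0.18 log units; within the scatter), changes nothing beyond the scatter. Compound 3 `Cc1ncnc2c1c(-c1cc3ccccc3o1)cn2[C@@H]1O[C@H](CO)[C@@H](O)[C@H]1O` gives in this assay only a limit, > 20000 nM, where the limit of > 20000 nM in this assay, at which 1 of the 3 values shown sits, applies.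

Compound 4 `CN(C)c1ncnc2c1c(-c1ccsc1)cn2[C@@H]1O[C@H](CO)[C@@H](O)[C@H]1O` differs from compound 2 in thiophen-3-yl in place of ethynyl on an aromatic carbon. For the measured compounds named here, no measured step exchanges the ethynyl group for a ring at that position, so the one step on record does not bear on this change. Going by the values given here, the only aryl-bearing analogue, compound 3, reports a limit rather than a number, and it also differs from compound 2 at the substituent on the shared core, so it gives no isolated reading of the ring exchange. A weakening beyond the scatter is therefore expected, but with wide uncertainty, and the estimated step is an 8.6-fold higher number from compound 2 to compound 4 (0.94 log units; beyond the scatter). Compound 4 is estimated at 2500 nM in this assay, with a range from 300 nM to 20000 nM.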

Compound 4, half-maximal inhibitory concentration: 1920 nM
For compound 4 the middle estimate is 1.3-fold (0.11 log units) above the measured one; measured number inside the range.
By their numbers in this assay, from the lowest: compounds 1 and 2 (each within the scatter of the next); then compound 4. At a limit, above all of these: compound 3.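

In this assay, the position on the five-membered aromatic ring, two ring bonds from the ring nitrogen, now has a measured step of its own: a 6.6-fold higher number from compound 2 to compound 4 (0.82 log units; beyond the scatter). For the compounds shown here, the one earlier step, a 1.5-fold higher number from compound 1 to compound 2 (0.18 log units; within the scatter), lay at the substituent on the shared core, so this exchange of ethynyl for thiophen-3-yl is the first single change to move the number beyond the scatter, and the size of that move is modest. Compound 3 differs from compound 4 in more than one place and gives only a limit, so it adds no comparison for this exchange: the limit of > 20000 nM in this assay, at which 1 of the 4 values shown sits.

On these data alone, it remains open whether a nitrile or a longer chain ending in a triple bond at this place would read nearer to compound 2 or nearer to compound 4, which would show how far the step follows the loss of the ethynyl group and how far the entry of the ring. Also open, as far as these compounds go, is whether the same exchange gives a step of similar size with methoxy on the shared core, as in compound 1.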